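The source may report more compounds than this note shows. Statements on the series, on what has been measured and on what is new or still open speak of the compounds shown alone.

Compounds measured so far:
- compound 1 `c1ccc(-c2cccc3c2CCC3c2ncc[nH]2)nc1`; in a functional assay on CHO cells for agonist activity at Alpha-1B adrenergic receptor (Homo sapiens), read by FLIPR and calcium flux (a higher number here means that more compound is needed for the effect, a lower number that less compound is needed), compound 1 gives only a limit, > 10000 nM.
- compound 2 `CCCS(=O)(=O)Nc1cccc2c1CCC2c1ncc[nH]1`; in this assay compound 2 likewise gives only a limit, > 10000 nM.

Compound 2 thus stands at the limit of the assay; both values shown sit there, as the limit of > 10000 nM in this assay, at which 2 of the 2 values shown sit, records, and the step that the two limits leave unreadable from compound 1 to compound 2 cannot be read.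

Compound 3 `Cn1ccc(-c2cccc3c2CCC3c2ncc[nH]2)n1` differs from compound 2 by 1-methyl-1H-pyrazol-3-yl in place of (propylsulfonyl)amino on an aromatic carbon. Among the measured compounds shown here, the only measured step, from compound 1 to compound 2, is unreadable, so no measured step gives a size for this change; the one comparable substituent, pyridin-2-yl in compound 1, also sits at the limit.

For compound 3 in this assay no potency beyond the limit is expected; the estimate is 20000 nM with a range of 5000 nM to 100000 nM. The step from compound 2 to compound 3 is expected to be a step that the limit leaves unreadable from compound 2 to compound 3, most likely again a limit rather than a number.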

Compound 3, half-maximal effective concentration: > 10000 nM
Compound 3: only a limit was reported; the forecaster's own chance of this, stated with the estimate: 80%; the middle value does not contradict the limit.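

In this assay compound 3 gives only a limit, > 10000 nM. The steps to compound 3 from compound 1 and compound 2 therefore cannot be read: the limit of > 10000 nM in this assay, at which 3 of the 3 values shown sit.

The compounds shown leave open whether any substituent at this aromatic carbon of the shared core gives a measurable value.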